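Extending the chain on the ring nitrogen of compound 1

The compounds below may be only part of what the source reports. "The series", "measured", "known", "first", "only" and "open" are said of these compounds alone.

Measured compounds:
compound 1 `COc1ccc(-c2cc3c(OC)cc(OC)cc3n(C)c2=O)cc1` gives 10000 nM
compound 2 `COC(=O)CCn1c(=O)c(-c2ccc(OC)cc2)cc2c(OC)cc(OC)cc21` gives 10000 nM
compound 3 `COc1ccc(-c2cc3c(OC)cc(OC)cc3n(CCC#N)c2=O)cc1` gives 10000 nM

In a functional assay on T47D cells (Homo sapiens) for cytotoxicity, read by colorimetric assay and MTT assay (on this read-out lower numbers stand for stronger inhibition and higher numbers for weaker inhibition), compound 1 stands level with compounds 2 and 3. Among the measured compounds shown here, compound 4 `COc1ccc(-c2cc3c(OC)cc(OC)cc3n(CCC(=O)OCc3ccccc3)c2=O)cc1` is not yet measured and differs from compound 1 in one place: (benzyloxycarbonyl)methyl in place of hydrogen on a saturated chain carbon bound to an aromatic nitrogen The steps that bear on this are those that also add a chain on the same nitrogen, no change at the digits printed from compound 1 to compound 2 (within the scatter) and no change at the digits printed from compound 1 to compound 3 (within the scatter); swapping the chain end, no change at the digits printed from compound 2 to compound 3 (within the scatter), also left the value unchanged. No step beyond the scatter is therefore expected, so compound 4 is estimated at 10000 nM (range 5000 nM to 20000 nM), a step of no change at the digits printed from compound 1 to compound 4 (within the scatter) that is expected to stay within the scatter.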

Compound 4, half-maximal inhibitory concentration: 10000 nM
Compound 4: the middle estimate sits on the measured number at the digits printed; measured number inside the range.
By their numbers in this assay, from the lowest: compounds 1, 2, 3 and 4 (each within the scatter of the next).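

In this assay, adding (benzyloxycarbonyl)methyl puts a six-membered aromatic ring of carbon only on the chain at the ring nitrogen, yet this larger group gives no change at the digits printed from compound 1 to compound 4 (within the scatter). Swapping the chain end for benzyloxycarbonyl in place of cyano gives no change at the digits printed from compound 3 to compound 4 (within the scatter), and phenyl in place of hydrogen on the ester gives no change at the digits printed from compound 2 to compound 4 (within the scatter), so even this bulkier chain end separates none of the compounds. No measurement shown here offers a reason for these level values.

Still open, going by these compounds, is whether a carboxylic acid or an amine at the chain end would shift the value. The same holds for a longer chain on this nitrogen.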